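The compounds below may be only part of what the source reports. "The series", "measured", "known", "first", "only" and "open" are said of these compounds alone.

Measured so far in an ADME assay on HepG2 2.2.15 cells (Homo sapiens) for cytotoxicity; a lower number here means that less compound is tolerated, a higher number that more compound is tolerated:
- compound 1 `CC(=O)OCCc1c(-c2ccccc2Cl)c2cc(Cl)ccc2[nH]c1=O`: 27000 nM
- compound 2 `CCCCCCCC(=O)OCCc1c(-c2ccccc2Cl)c2cc(Cl)ccc2[nH]c1=O`: 78000 nM
- compound 3 `O=C(OCCc1c(-c2ccccc2Cl)c2cc(Cl)ccc2[nH]c1=O)c1cccnc1`: 170000 nM

Compound 3 has the highest number of the three, so it is the best tolerated by the cells. The next structure is compound 4 `O=C(/C=C/c1ccccc1)OCCc1c(-c2ccccc2Cl)c2cc(Cl)ccc2[nH]c1=O`, which has not yet been measured. It carries 2-phenylethenyl in place of pyridin-3-yl on a carbonyl carbon.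

The measured compounds differ only in the group on that carbonyl, and the steps among them were modest: a 2.9-fold higher number from compound 1 to compound 2 (0.46 log units; beyond the scatter), a 6.3-fold higher number from compound 1 to compound 3 (0.80 log units; beyond the scatter) and a 2.2-fold higher number from compound 2 to compound 3 (0.34 log units; beyond the scatter). None of them replaces one ring-bearing group with another, so the guidance is indirect. The closest guide is a 2.2-fold higher number from compound 2 to compound 3 (0.34 log units; beyond the scatter), where pyridin-3-yl replaced heptyl, another group without nitrogen. Losing pyridin-3-yl again should therefore give a modest step to a lower number in this assay, though a change within the scatter remains possible. The estimated step is a 2.3-fold lower number from compound 3 to compound 4 (0.36 log units; beyond the scatter). For compound 4 the expected value is 75000 nM, with an estimated range from 25000 nM to 180000 nM.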

Compound 4, half-maximal cytotoxic concentration: 230000 nM
Beside the measured number, compound 4's estimate is 3.1-fold (0.49 log units) below it; the measured number lies above the stated range.
By their numbers in this assay, from the lowest: compound 1; then compound 2; then compounds 3 and 4 (each within the scatter of the next).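

In this assay, swapping pyridin-3-yl for 2-phenylethenyl on this carbonyl gives a 1.4-fold higher number from compound 3 to compound 4 (0.13 log units; within the scatter), so a ring of carbon only with a double bond outside it reads the same here as a ring containing nitrogen. The two chains stay apart from this new group, with a 2.9-fold higher number from compound 2 to compound 4 (0.47 log units; beyond the scatter) and an 8.5-fold higher number from compound 1 to compound 4 (0.93 log units; beyond the scatter), so among these four compounds the two groups bearing an aromatic ring give the higher numbers, and no compound goes against that. No measured evidence explains these differences.

As far as these compounds go, it remains open whether the aromatic ring alone is enough, which phenyl placed directly on the carbonyl would test by removing the double bond. From the compounds shown here alone, how a group carrying an amine or a carboxylic acid would behave at this position also remains open.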